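Trimming diethylamino to ethyl(methyl)amino

The source may hold more compounds than are shown below. What is called first, only, known or untested is meant among the compounds shown, and "the series" means these compounds.

In a functional assay on A549 cells (Homo sapiens) for antiproliferative activity, read by MTT assay, with a stated time of 72 h (on this read-out higher numbers stand for weaker inhibition and lower numbers for stronger inhibition), compound 1 `CC(C)CNC(=N)NC(=N)Nc1ccc(C(F)(F)F)cc1` gives 1300 nM and compound 2 `CCN(CC)C(=N)NC(=N)Nc1ccc(C(F)(F)F)cc1` gives 3700 nM as the higher of the two numbers. Compound 3 `CCN(C)C(=N)NC(=N)Nc1ccc(C(F)(F)F)cc1` differs from compound 2 by hydrogen in place of methyl on a saturated chain carbon bound to an amine nitrogen in one spot, with hydrogen in place of methyl on a saturated chain carbon bound to an amine nitrogen. For the measured compounds named here, the only measured step bearing on this is a 2.8-fold higher number from compound 1 to compound 2 (0.45 log units; beyond the scatter) and it is modest. The new change removes just one methyl, so a small step of a 1.2-fold lower number from compound 2 to compound 3 (0.09 log units; within the scatter) is expected, not beyond the scatter. Compound 3 is estimated at 3000 nM with an expected range from 1400 nM to 6500 nM in repeat measurements.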

Compound 3, half-maximal inhibitory concentration: 4100 nM
For compound 3 the middle estimate is 1.4-fold (0.14 log units) below the measured one, and the stated range covers the measured number.
By their numbers in this assay, from the lowest: compound 1; then compounds 2 and 3 (each within the scatter of the next).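

In this assay, taking one methyl off the diethylamino group makes no readable difference, with a 1.1-fold higher number from compound 2 to compound 3 (0.04 log units; within the scatter). The distance from the isobutylamino group remains, with a 3.2-fold higher number from compound 1 to compound 3 (0.50 log units; beyond the scatter), so shortening this chain by one carbon does not bring the number closer to that of compound 1. No supporting data are available to explain either result.

Open, as far as these compounds go, is whether dimethylamino, with a further methyl in place of ethyl, would stay level with compound 3. Also open, from the compounds shown here alone, is whether ethylamino, which keeps a hydrogen on that nitrogen, would fall nearer compound 1.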